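A few compounds are considered here, and "the series" means these few. Any claim that something is new, unique, unknown or untested is made for them only; others in the source may bear on it.

In a physicochemical assay for acid dissociation, compound 3 (`COC(=O)c1cc(S(N)(=O)=O)ccc1SCCCO`) gives 9.3 and lies within the scatter of compound 1 (`NS(=O)(=O)c1ccc(S(=O)(=O)CCCO)c(F)c1`) at 9.02. Compound 2 (`NS(=O)(=O)c1ccc(S(=O)(=O)CCCO)c([N+](=O)[O-])c1`) gives 8 on the same scale. Compound 3 lies beyond the scatter of compound 2. The move to compound 4 (`COC(=O)c1cc(S(N)(=O)=O)ccc1S(=O)(=O)CCCO`) is (3-hydroxypropyl)sulfonyl in place of (3-hydroxypropyl)sulfanyl on an aromatic carbon, ortho to a methoxycarbonyl group and para to a sulfamoyl group ((3-hydroxypropyl)sulfonyl in place of (3-hydroxypropyl)sulfanyl on an aromatic carbon). Within the data shown here, no measured step makes this exchange. Among the measured compounds shown here, the only step available, a number 1.02 log units lower from compound 1 to compound 2 (beyond the scatter) for nitro in place of fluoro, is large but concerns another group, and both of its compounds already carry the sulfonyl chain. A moderate move to a lower number is therefore expected, estimated as a number 0.70 log units lower from compound 3 to compound 4 (beyond the scatter) and beyond the scatter. Compound 4 is estimated at 8.6 (expected range 8.2 to 9).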

Compound 4, acid dissociation constant: 8.9
Compound 4: middle estimate off by 0.30 log units, on the low side; the range from low to high includes it.
By their numbers in this assay, from the lowest: compound 2; then compounds 4, 1 and 3 (each within the scatter of the next, the first and the last beyond it).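

In this assay the exchange of (3-hydroxypropyl)sulfanyl for (3-hydroxypropyl)sulfonyl, ortho to a methoxycarbonyl group and para to a sulfamoyl group, now has its own reading: a number 0.40 log units lower from compound 3 to compound 4 (beyond the scatter). With the sulfonyl chain kept, methoxycarbonyl in place of nitro gives a number 0.90 log units higher from compound 2 to compound 4 (beyond the scatter), whereas methoxycarbonyl in place of fluoro gives a number 0.12 log units lower from compound 1 to compound 4 (within the scatter). No measurement at hand gives a reason for these steps.

Going by these compounds, whether the sulfonyl exchange has the same size with fluoro or nitro in place of methoxycarbonyl remains open. So does the reading with an amine or a carboxylic acid at that carbon.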